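Trimming the basic side chain of compound 1

This account rests on a few compounds, and the source may have more. Where it says the series, first, only, none or still open, it means among the compounds named here.

Of the compounds shown here, three sharing one core have been measured. In a functional assay on NCI-H1975 cells (Homo sapiens) for antiproliferative activity, read by MTT assay, with a stated time of 72 h (a higher number here means a weaker inhibitor, a lower number a stronger inhibitor), compound 1 `COc1cc(N(C)CCN(C)C)c(NC(=O)c2ccnc(Cl)c2)cc1Nc1nccc(-c2cn(C)c3ccccc23)n1` gives 2050 nM, which is the highest number of the three. Compound 2 `COc1cc(N(C)CCN(C)C)c(NC(=O)c2ccncc2OC)cc1Nc1nccc(-c2cn(C)c3ccccc23)n1` gives 1010 nM in this assay, and compound 3 `COc1cc(N(C)CCN(C)C)c(NC(=O)c2cccnc2)cc1Nc1nccc(-c2cn(C)c3ccccc23)n1` gives 1750 nM. The step of a 2.0-fold lower number from compound 1 to compound 2 (0.31 log units; beyond the scatter) is beyond the scatter, while a 1.2-fold lower number from compound 1 to compound 3 (0.07 log units; within the scatter) and a 1.7-fold higher number from compound 2 to compound 3 (0.24 log units; within the scatter) are within it. All three of these steps change only the ring attached to the carbonyl carbon of the amide.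

Compound 4 `COc1cc(N(C)C)c(NC(=O)c2ccnc(Cl)c2)cc1Nc1nccc(-c2cn(C)c3ccccc23)n1` keeps the amide of compound 1 and differs elsewhere: hydrogen in place of (dimethylamino)methyl on a saturated chain carbon bound to a nitrogen on an aromatic ring. Among the compounds with values here, none of the measured steps touches this part of the molecule, so there is no directly comparable step to lean on. The expectation is therefore a cautious one with a wide range: compound 4 is estimated at 3000 nM in this assay, between 1000 nM and 10000 nM, which means an expected step of a 1.5-fold higher number from compound 1 to compound 4 (0.17 log units; within the scatter).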

Compound 4, half-maximal inhibitory concentration: 9200 nM
Compound 4: middle estimate off by 3.1-fold (0.49 log units), on the low side; the measured number falls inside the stated range.
By their numbers in this assay, from the lowest: compounds 2, 3 and 1 (each within the scatter of the next, the first and the last beyond it); then compound 4.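

In this assay, within the data shown here, the step of a 4.5-fold higher number from compound 1 to compound 4 (0.65 log units; beyond the scatter) is the first measured change outside the ring on the amide carbonyl, and it shows that the number depends on this side chain as well. Going from (2-(dimethylamino)ethyl)(methyl)amino to dimethylamino gives a step beyond the scatter, and it is larger than any step among the three amide variants, the biggest of which is a 2.0-fold lower number from compound 1 to compound 2 (0.31 log units; beyond the scatter). No measurement available here accounts for this rise.

On these data alone, what remains open is whether the dimethylamino group itself matters or simply the chain length, which a longer chain such as 3-(dimethylamino)propyl, or a morpholine at the end of the ethyl chain, could help separate. As far as these compounds go, it is also open whether trimming the chain has the same effect when the amide ring is that of compound 2 or compound 3.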